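Working notes: butylcarbonyl to propyl on the oxygen

The source may report more compounds than this note shows. Statements on the series, on what has been measured and on what is new or still open speak of the compounds shown alone.

Measured in a functional assay on A549 cells (Homo sapiens) for cytotoxicity, with a stated time of 48 h; on this read-out higher numbers stand for weaker inhibition and lower numbers for stronger inhibition:
- compound 1 `CCCCCOc1ccc2oc(/C=C/[S+](C)[O-])cc(=O)c2c1` gives 1600 nM
- compound 2 `CCCC(=O)Oc1ccc2oc(/C=C/[S+](C)[O-])cc(=O)c2c1` gives 2200 nM
- compound 3 `CCCCC(=O)Oc1ccc2oc(/C=C/[S+](C)[O-])cc(=O)c2c1` gives 2400 nM

Compound 3, at 2400 nM, cannot be separated from the other two compounds. Both a 1.1-fold higher number from compound 2 to compound 3 (0.04 log units; within the scatter) and a 1.5-fold higher number from compound 1 to compound 3 (0.18 log units; within the scatter) stay within the scatter, as does a 1.4-fold higher number from compound 1 to compound 2 (0.14 log units; within the scatter).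

The next compound is compound 4 `CCCOc1ccc2oc(/C=C/[S+](C)[O-])cc(=O)c2c1`, and the change from compound 3 is propyl in place of butylcarbonyl on an oxygen on an aromatic ring. In words, this is propyl in place of butylcarbonyl on an oxygen on an aromatic ring.

The closest measured parallel is a 1.5-fold higher number from compound 1 to compound 3 (0.18 log units; within the scatter), which exchanges pentyl and butylcarbonyl on the same oxygen, read here in the opposite direction. The exchange with propylcarbonyl, a 1.4-fold higher number from compound 1 to compound 2 (0.14 log units; within the scatter), is of similar size. Lengthening the acyl chain, a 1.1-fold higher number from compound 2 to compound 3 (0.04 log units; within the scatter), also left the numbers within the scatter. Among the measured compounds shown here, no measured pair compares two chains that both lack the carbonyl, so the shortening from pentyl to propyl remains untested, and three compounds are thin evidence.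

No step beyond the scatter is therefore expected in this assay, with at most a slight drift towards the number of compound 1. The expected step is a 1.3-fold lower number from compound 3 to compound 4 (0.10 log units; within the scatter). Compound 4 is estimated at 1900 nM, with an expected range of 1000 nM to 3500 nM.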

Compound 4, half-maximal inhibitory concentration: 1100 nM
For compound 4 the middle estimate is 1.7-fold (0.24 log units) above the measured one; measured number inside the range.
By their numbers in this assay, from the lowest: compounds 4, 1, 2 and 3 (each within the scatter of the next, the first and the last beyond it).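

Among the compounds shown here, at this oxygen on an aromatic ring, propyl in place of butylcarbonyl gives the first step that lies beyond the scatter, a modest one in this assay (a 2.2-fold lower number from compound 3 to compound 4 (0.34 log units; beyond the scatter)). The separation is confined to that one pair, as the other two comparisons stay within the scatter, the exchange with propylcarbonyl (a 2.0-fold lower number from compound 2 to compound 4 (0.30 log units; within the scatter)) and the shorter of the two chains without a carbonyl (a 1.5-fold lower number from compound 1 to compound 4 (0.16 log units; within the scatter)), so the position tolerates all four groups with only a small spread in the numbers. Nothing at hand accounts for the step between compound 3 and compound 4.

Still open, on these data alone, is whether the numbers keep within this narrow band with other groups on the same oxygen, such as a methyl, a longer chain of eight or more carbons, or a chain ending in an amine or a carboxylic acid. Also open, as far as these compounds go, is whether the modest separation of compound 4 from compound 3 holds on other cell lines, since a single pair in one read-out is all that supports it.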